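The compounds below may be only part of what the source reports. "The series", "measured", "known", "first", "only" and "open" are said of these compounds alone.

Measured compounds:

Compound 1, `O=C(O)Cn1c(=O)c(/C=C/c2ccc(O)c(O)c2)nc2cc(Cl)cnc21`, in a functional assay, read by spectrophotometry, with a stated time of 30 min, tested at 100 uM (a higher number here means a stronger effect of the compound at the concentration tested, a lower number a weaker effect), gives 97.1%.
Compound 2, `COc1cc(/C=C/c2nc3cc(Cl)cnc3n(CC(=O)O)c2=O)ccc1O`, in this assay gives 94.9%.
Compound 3, `COc1c(O)cc(-c2nc3cccnc3n(CC(=O)O)c2=O)cc1O`, in this assay gives 45.6%.

Compound 2 differs from compound 1 by methyl in place of hydrogen on an oxygen on an aromatic ring, and this change gave a number 2.2 percentage points lower from compound 1 to compound 2 (within the scatter). Compound 3 shares part of its makeup with compound 1, but the difference between the two cores is not broken down here. Compound 3 stands lowest of the three measured values, well separated from compound 1 and compound 2.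

Compound 4, `COc1cc(-c2nc3cccnc3n(CC(=O)O)c2=O)cc(O)c1OC`, is not yet measured. It differs from compound 3 by methyl in place of hydrogen on an oxygen on an aromatic ring, the same change in the same kind of place as from compound 1 to compound 2. Since that earlier step stayed within the scatter, the step expected is a number 2.6 percentage points lower from compound 3 to compound 4 (within the scatter). Compound 4 is therefore estimated at 43%, between 30% and 58%.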

Compound 4, a percentage reported as activity, at one concentration (the size of the read-out at that concentration, not a potency): 20.5%
Beside the measured number, compound 4's estimate is 22.5 percentage points above it, outside the stated range (below it).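

In this assay, swapping hydroxy for methoxy gave a number 25.1 percentage points lower from compound 3 to compound 4 (beyond the scatter), so a change that was small on one core was not small on the other. The same change therefore did not carry over at the same size between these two cores: the same change on two cores in this assay, a number 2.2 percentage points lower (within the scatter) from compound 1 to compound 2 and a number 25.1 percentage points lower (beyond the scatter) from compound 3 to compound 4, 22.9 percentage points apart, beyond the scatter of two such steps. Two pairs cannot show which feature of the cores sets the size of the step, nor how a third core would respond.

As far as these compounds go, it remains open whether a longer chain on that oxygen, such as ethyl, would lower the number further on the core of compound 3. From the compounds shown here alone, it is also open how an amine in place of that hydroxy would read on either core.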